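Trisubstituted anilides: swapping the warhead on the carbonyl

The source may report more compounds than this note shows. Statements on the series, on what has been measured and on what is new or still open speak of the compounds shown alone.

Measured compounds:
Compound 1, `C#CC(=O)N(Cc1ccc(OC)c(O)c1)c1cc(OC)c(OC)c(OC)c1`: 570 nM
Compound 2, `COc1ccc(CN(C(=O)CCl)c2cc(OC)c(OC)c(OC)c2)cc1O`: 210 nM
Compound 3, `COc1ccc(CN(C(=O)CN=[N+]=[N-])c2cc(OC)c(OC)c(OC)c2)cc1O`: 160 nM

All three share one core and differ only in the small group carried on the carbonyl carbon. In a functional assay on KYSE-450 cells (Homo sapiens) for inhibition, read by MTT assay, with a stated time of 48 h (a lower number here means a stronger inhibitor, a higher number a weaker inhibitor), compound 3 gives the lowest of the three numbers, but the step of a 1.3-fold lower number from compound 2 to compound 3 (0.12 log units; within the scatter) lies within the scatter, so compounds 2 and 3 cannot be told apart. Compound 1, with ethynyl on the carbonyl carbon, gives a clearly higher number: a 3.6-fold lower number from compound 1 to compound 3 (0.55 log units; beyond the scatter) and a 2.7-fold lower number from compound 1 to compound 2 (0.43 log units; beyond the scatter).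

Compound 4, `C=CC(=O)N(Cc1ccc(OC)c(O)c1)c1cc(OC)c(OC)c(OC)c1`, has not yet been measured. It differs from compound 3 as follows: vinyl in place of azidomethyl on a carbonyl carbon. Going by the values given here, no measured step carries a vinyl group, so there is no direct precedent. Among the compounds with values here, the steps that bear on the question are a 3.6-fold lower number from compound 1 to compound 3 (0.55 log units; beyond the scatter) and a 2.7-fold lower number from compound 1 to compound 2 (0.43 log units; beyond the scatter), which show that the two substituted-methyl groups beat ethynyl by a modest margin; vinyl, like ethynyl, is a small unsaturated carbon group. A step back toward the number of compound 1 is therefore expected, modest in size and toward a higher number, as a 2.2-fold higher number from compound 3 to compound 4 (0.34 log units; beyond the scatter). Compound 4 is accordingly estimated at 350 nM in this assay, with a range from 150 nM to 800 nM.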

Compound 4, half-maximal inhibitory concentration: 160 nM
For compound 4 the middle estimate is 2.2-fold (0.34 log units) above the measured one, within the range that was stated.
By their numbers in this assay, from the lowest: compounds 3, 4 and 2 (each within the scatter of the next); then compound 1.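

In this assay the new compound gives no change at the digits printed from compound 3 to compound 4 (within the scatter) and a 1.3-fold lower number from compound 2 to compound 4 (0.12 log units; within the scatter) as well, so vinyl, azidomethyl and chloromethyl on this carbonyl carbon cannot be told apart. Ethynyl now stands alone among the four groups, with a 3.6-fold lower number from compound 1 to compound 4 (0.55 log units; beyond the scatter) as its step to vinyl, which shows that two unsaturated carbon groups in the same place need not give the same result, and that a multiple bond at this carbon does not by itself go with the higher number. No measurement available here explains why ethynyl parts from the other three groups.

The compounds shown leave open whether a plain methyl or ethyl group on the carbonyl carbon, with no chlorine, azide or multiple bond, would match compounds 2, 3 and 4 or fall nearer compound 1, so it remains unknown how much any of these groups contributes beyond simply being present. Also open, as far as these compounds go, is whether a longer chain, such as propenyl or butynyl in place of vinyl or ethynyl, would keep or lose the number seen here.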